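Nitro in Place of Bromo on a Shared Core

The source may hold more compounds than are shown below. What is called first, only, known or untested is meant among the compounds shown, and "the series" means these compounds.

Of the compounds shown here, three that share one core have been measured in a functional assay on cells (Cancer cell lines, Homo sapiens) for inhibition; a higher number here means a weaker inhibitor of growth, a lower number a stronger inhibitor of growth. Compound 1 `COc1ccc(-c2nc3sc(Cc4ccccc4)nn3c2SC#N)cc1` gives 7900 nM in this assay. Compound 2 `Clc1ccc(-c2cn3nc(Cc4ccccc4)sc3n2)cc1` gives 2600 nM. Compound 3 `O=Cc1c(-c2ccc(Br)cc2)nc2sc(Cc3ccccc3)nn12` gives 3200 nM, the second highest of the three numbers. Its nearest neighbour is compound 2, whose number is lower by a margin that lies within the usual scatter, so no order between compounds 2 and 3 can be claimed. Its furthest neighbour is compound 1, whose number is higher by a margin beyond the scatter. No pair of these compounds differs in only one place, so no single structural step has been measured.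

The next compound, compound 4 `O=Cc1c(-c2ccc([N+](=O)[O-])cc2)nc2sc(Cc3ccccc3)nn12`, differs from compound 3 in one place: nitro in place of bromo on an aromatic carbon The change sits on an aromatic carbon of a six-membered aromatic ring of carbon only. Nothing in the measured set shows how this assay responds to such a change, so the expectation rests on compound 3 alone. The step from compound 3 to compound 4 is expected to be no change at the digits printed from compound 3 to compound 4 (within the scatter), that is, none beyond the scatter. Compound 4 is therefore expected to give about 3200 nM, with a range from 1100 nM to 9500 nM.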

Compound 4, concentration for 50% growth inhibition: 3700 nM
For compound 4 the middle estimate is 1.2-fold (0.06 log units) below the measured one; the measured number falls inside the stated range.
By their numbers in this assay, from the lowest: compounds 2, 3 and 4 (each within the scatter of the next); then compound 1.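

Going by these compounds alone, compound 4 supplies the first step that changes one place only: in this assay, nitro in place of bromo on an aromatic carbon, para to a large group, gives a 1.2-fold higher number from compound 3 to compound 4 (0.06 log units; within the scatter) and so stays within the scatter. The earlier compounds shown here could not show this, as none of them formed such a pair, whereas here a single bromine atom gives way to a group of three heavy atoms with two hydrogen-bond acceptors and the read-out shows no change beyond the scatter. No accompanying measurement offers an explanation of why this exchange leaves the number within the scatter.

This single pair does not show whether the position is generally insensitive to its substituent, and an amine, a carboxylic acid or a longer chain on the same aromatic carbon could still give a step beyond the scatter. It also leaves open whether nitro in place of bromo would read the same way with a different group on the rest of the shared core, since the step has been seen in only one setting.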